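Furan-2-yl in Place of Naphthalen-1-yl: Compound 4

The source may hold more compounds than are shown below. What is called first, only, known or untested is meant among the compounds shown, and "the series" means these compounds.

Compound 1 `COc1ccc(/C=C/C(=O)/C=C/c2ccc(OCc3cn(CCCCCOc4cc(=O)oc5ccccc45)nn3)c(OC)c2)cc1`: 30%
Compound 2 `COc1ccccc1/C=C/C(=O)/C=C/c1ccc(OCc2cn(CCCCOc3cc(=O)oc4ccccc34)nn2)c(OC)c1`: 47%
Compound 3 `COc1cc(/C=C/C(=O)/C=C/c2cccc3ccccc23)ccc1OCc1cn(CCCCOc2cc(=O)oc3ccccc23)nn1`: 50%

In a functional assay on COLO 205 cells (Homo sapiens) for inhibition, read by sulforhodamine B assay, with a stated time of 48 h, tested at 50 uM (a higher number here means more inhibition of growth at the concentration tested, a lower number less inhibition of growth), compound 3 gives 50%, the highest of the three numbers. Its distance from compound 1 lies beyond the scatter, while its distance from compound 2 lies within it: a number 3 percentage points higher from compound 2 to compound 3 (within the scatter). Among the measured compounds shown here, that one step is the only comparison at the same place on the chain, and it shows that exchanging 2-methoxyphenyl for naphthalen-1-yl did not move the number beyond the scatter.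

Compound 4 `COc1cc(/C=C/C(=O)/C=C/c2ccco2)ccc1OCc1cn(CCCCOc2cc(=O)oc3ccccc23)nn1` differs from compound 3 in that very place: furan-2-yl in place of naphthalen-1-yl on a double-bonded chain carbon bound to a double-bonded chain carbon. For the measured compounds named here, no measured step covers furan-2-yl, so there is no direct precedent for this change. Given that the one exchange at this position, from compound 2 to compound 3, stayed within the scatter, a modest change at most is expected in this assay, with a number 8 percentage points lower from compound 3 to compound 4 (within the scatter) as the estimated step. Compound 4 is therefore expected to give about 42%, within a range from 25% to 60%.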

Compound 4, percent growth inhibition at one concentration: 43%
Compound 4: middle estimate off by 1 percentage points, on the low side, and the stated range covers the measured number.
By their numbers in this assay, from the lowest: compound 1; then compounds 4, 2 and 3 (each within the scatter of the next).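

In this assay, the step of a number 7 percentage points lower from compound 3 to compound 4 (within the scatter) shows that this place on a double-bonded chain carbon bound to a double-bonded chain carbon can take a far smaller group, one five-membered aromatic ring with 1 hetero atom, in place of two six-membered aromatic rings, without the number leaving the scatter. The step of a number 4 percentage points lower from compound 2 to compound 4 (within the scatter) adds that furan-2-yl and 2-methoxyphenyl also cannot be told apart here, so all three groups at this place, in compounds 2, 3 and 4, give numbers within the scatter of one another. Nothing available explains why these exchanges leave the number so little changed.

On these data alone, whether an amine or a carboxylic acid at this place would carry the number beyond the scatter remains open. Compound 1 differs from the others in more than one place, so its lower number cannot be assigned to any single change.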